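Chalcones on the shared core: a chloro-hydroxyphenyl variant

The source may report more compounds than this note shows. Statements on the series, on what has been measured and on what is new or still open speak of the compounds shown alone.

Compound 3 `COc1ccc(C(=O)/C=C/c2ccc(O)c(Br)c2)c2c1C=CC(C)(C)O2` stands only at a limit on the numbers shown. In a functional assay on HCT-116 cells (Homo sapiens) for antiproliferative activity, read by MTT assay, with a stated time of 24 h (on this read-out higher numbers stand for weaker inhibition and lower numbers for stronger inhibition), compound 3 gives > 10000 nM, which is a limit of the assay and not a number. Compound 1 `COc1ccc(C(=O)/C=C/c2ccc(F)cc2)c2c1C=CC(C)(C)O2` sits at the same limit: in this assay compound 1 gives > 10000 nM, again a limit rather than a number. Compound 2 `COc1ccc(C(=O)/C=C/c2cccc(F)c2)c2c1C=CC(C)(C)O2` does likewise: in this assay compound 2 gives > 10000 nM, once more a limit. The measured steps that bear on the new change are a step that the two limits leave unreadable from compound 1 to compound 2, a step that the two limits leave unreadable from compound 1 to compound 3 and a step that the two limits leave unreadable from compound 2 to compound 3; none of them has a readable size, since every value shown rests at the limit of > 10000 nM in this assay, at which 3 of the 3 values shown sit. The variation of the aryl group among compounds 1, 2 and 3 therefore gives no direction at all.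

Compound 4 `COc1ccc(C(=O)/C=C/c2cc(Cl)ccc2O)c2c1C=CC(C)(C)O2` differs from compound 3 by 5-chloro-2-hydroxyphenyl in place of 3-bromo-4-hydroxyphenyl on a double-bonded chain carbon bound to a double-bonded chain carbon. With no readable step among the measured compounds, no step beyond the scatter is expected in this assay, and the estimated step from compound 3 to compound 4 is a step that the limit leaves unreadable from compound 3 to compound 4. Compound 4 is expected to give about 15000 nM in this assay, within a range of 4000 nM to 60000 nM, and most probably to be reported again only as a limit.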

Compound 4, half-maximal inhibitory concentration: 5240 nM
Beside the measured number, compound 4's estimate is 2.9-fold (0.46 log units) above it; measured number inside the range.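

Compound 4 is the only compound shown that gives a number rather than a limit in this assay, so the place on a double-bonded chain carbon bound to a double-bonded chain carbon now carries one readable value, with 5-chloro-2-hydroxyphenyl on it. Against the three other aryl groups the steps are an at least 1.9-fold lower number from compound 3 to compound 4 (0.28 log units; that floor lies within the scatter), an at least 1.9-fold lower number from compound 2 to compound 4 (0.28 log units; that floor lies within the scatter) and an at least 1.9-fold lower number from compound 1 to compound 4 (0.28 log units; that floor lies within the scatter), so none of them shows a change beyond the scatter. Each is only a floor, the steps among compound 1, compound 2 and compound 3 still cannot be read, and the true sizes stay hidden because the other compounds rest at one limit: the limit of > 10000 nM in this assay, at which 3 of the 4 values shown sit.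

Compound 3 and compound 4 differ in the halogen and in the arrangement of the aryl substituents together, so the compounds shown cannot say which of these, if either, goes with the number seen for compound 4. Also open, from the compounds shown here alone, is what this assay would give with 5-bromo-2-hydroxyphenyl at this place, or with an amine or a carboxylic acid in place of the hydroxyl on the aryl group.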